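A Ring Swap Beside a Single Measured Value

This account rests on a few compounds, and the source may have more. Where it says the series, first, only, none or still open, it means among the compounds named here.

This piece follows a small change to one compound, judged by how strongly each compound holds back the growth of cultured cells. Compound 1 `COc1ccc2nccc(CC[C@H]3CC[C@H](NCc4ccc(Cl)c(Cl)c4)CC3)c2c1` offers no help as a comparison: in an ADME assay on K562 cells (Homo sapiens) for antiproliferative activity (on this read-out higher numbers stand for weaker inhibition and lower numbers for stronger inhibition), compound 1 gives "not determined" (no result reported). In the same test compound 2 `COc1ccc2nccc(CC[C@H]3OC[C@H](NCc4cc5c(cn4)OCCO5)CO3)c2c1` gives 40000 nM. Going by the values given here, that is the only number available, so compound 2 cannot yet be ranked against anything.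

Compound 3 `COc1ccc2nccc(CC[C@H]3OC[C@H](NCc4ccc5c(n4)NC(=O)CS5)CO3)c2c1` keeps most of compound 2 and alters one group: a group of 11 heavy atoms (7 carbon, 2 nitrogen, 1 oxygen, 1 sulfur; one six-membered non-aromatic ring with 2 hetero atoms, one six-membered aromatic ring with 1 hetero atom) in place of a group of 10 heavy atoms (7 carbon, 1 nitrogen, 2 oxygen; one six-membered non-aromatic ring with 2 hetero atoms, one six-membered aromatic ring with 1 hetero atom), on a saturated chain carbon bound to an amine nitrogen. Both groups hold one six-membered non-aromatic ring with 2 hetero atoms and one six-membered aromatic ring with 1 hetero atom. The change sits on a saturated chain carbon bound to an amine nitrogen.

Among the compounds with values here, no measured pair shows how much such a swap matters here. Within the data shown here, the only anchor is compound 2 at 40000 nM, so no shift beyond the usual scatter is expected in this assay, and any direction is uncertain. The expected step of a 1.1-fold lower number from compound 2 to compound 3 (0.06 log units; within the scatter) is therefore small. For compound 3 the estimated value is 35000 nM, with an expected range of 12000 nM to 100000 nM.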

Compound 3, half-maximal inhibitory concentration: 31000 nM
For compound 3 the middle estimate is 1.1-fold (0.05 log units) above the measured one; the range from low to high includes it.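

Going by these compounds alone, the swap on a saturated chain carbon bound to an amine nitrogen gives the first measured step at this position: in this assay it comes with a 1.3-fold lower number from compound 2 to compound 3 (0.11 log units; within the scatter), so the two compounds cannot be told apart in this test. The two groups are not close copies: the entering group carries a sulfur atom and 1 hydrogen-bond donor, whereas the leaving group has 0 hydrogen-bond donors. Yet this exchange produces no shift that can be separated from ordinary repeat variation. Nothing available offers an independent measurement that could explain this result.

Several things changed together in this single swap, so the compounds shown cannot say whether the sulfur atom, the carbonyl or the amide hydrogen would matter on its own, and compound 1, with no reported result, offers no step that can be read. Going by these compounds, it also remains unknown whether a much more different group at this place, such as a carboxylic acid or a longer chain, would move the number beyond the usual scatter.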